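The source may hold more compounds than are shown below. What is called first, only, known or untested is meant among the compounds shown, and "the series" means these compounds.

In a functional assay on COLO 205 cells (Homo sapiens) for antiproliferative activity (on this read-out lower numbers stand for stronger inhibition of growth and higher numbers for weaker inhibition of growth), compound 1 `COC(=O)CCCCCCCCCCCCCC/C=C1\CC(CO)(COC(=O)C(C)(C)C)OC1=O` gives 3.86 ug/mL and compound 2 `CC(C)(C)C(=O)OCC1(CO)C/C(=C\CCCCCCCCCCCO)C(=O)O1` gives 2.49 ug/mL, and the gap between them is a 1.6-fold lower number from compound 1 to compound 2 (0.19 log units; within the scatter). In this assay compound 3 `CC(C)(C)C(=O)OCC1(CO)C/C(=C\CCCCCCCCCCCCCCC=O)C(=O)O1` is reported only as a limit, > 10 ug/mL. The measured steps that reach this limit are an at least 2.5-fold higher number from compound 1 to compound 3 (0.41 log units; beyond the scatter) and an at least 4.0-fold higher number from compound 2 to compound 3 (0.60 log units; beyond the scatter).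

Compound 4 `CC(C)(C)C(=O)OCCCCCCCCCCCCCCC/C=C1\CC(CO)(COC(=O)C(C)(C)C)OC1=O` changes the far end of the chain of compound 3: (((tert-butyl)carbonyl)oxy)methyl in place of formyl on a saturated chain carbon, ten or more bonds along the chain from a double-bonded chain carbon. Formyl leaves, and (((tert-butyl)carbonyl)oxy)methyl enters on a saturated chain carbon. Compound 4 has no formyl, like compound 1 and compound 2, and both of those gave numbers on the lower side of the limit. A move to a lower number in this assay is therefore expected, roughly the measured steps run in reverse. Within the data shown here, no measured compound carries the entering group, so the size remains uncertain, and another limit cannot be ruled out. The estimated step is an at least 2.0-fold lower number from compound 3 to compound 4 (0.30 log units; that floor lies within the scatter). Compound 4 is expected at 5 ug/mL, within an estimated range from 2 ug/mL to 14 ug/mL.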

Compound 4, concentration for 50% growth inhibition: 0.597 ug/mL
Compound 4: middle estimate off by 8.4-fold (0.92 log units), on the high side, outside the stated range (below it).
By their numbers in this assay, from the lowest: compound 4; then compounds 2 and 1 (each within the scatter of the next). At a limit, above all of these: compound 3.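

The far end of the chain does more than avoid formyl: in this assay, (((tert-butyl)carbonyl)oxy)methyl at this position gives a 4.2-fold lower number from compound 2 to compound 4 (0.62 log units; beyond the scatter) and a 6.5-fold lower number from compound 1 to compound 4 (0.81 log units; beyond the scatter), whereas the earlier change between hydroxy and 3-(methoxycarbonyl)propyl stayed within the scatter. Against the formyl end the change reads an at least 16-fold lower number from compound 3 to compound 4 (1.22 log units; beyond the scatter). That step is only a floor, since compound 3 is reported as a limit and not as a number: the limit of > 10 ug/mL in this assay, at which 1 of the 4 values shown sits.

The compounds shown do not tell whether an acetate or benzoate ester, a carboxylic acid or an amine at this chain end would give a similarly low number. They also leave open whether a shorter chain ending in the same ester would do so.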